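Fluoro to Trifluoromethyl: Expected Cytotoxicity of Compound 4

The compounds below may be only part of what the source reports. "The series", "measured", "known", "first", "only" and "open" are said of these compounds alone.

Measured compounds:
compound 1 `Cn1ccc2c(Oc3ccc(NC(=O)c4nn(-c5ccc(Cl)cc5)ccc4=O)cc3)ccnc21` – > 60000 nM
compound 2 `Cc1cc(=O)n(-c2cccc(F)c2)nc1C(=O)Nc1ccc(Oc2ncnc3[nH]ccc23)cc1` – 3180 nM
compound 3 `Cc1cc(=O)n(-c2cccc(F)c2)nc1C(=O)Nc1ccc(Oc2ncnc3[nH]ccc23)c(F)c1` – 23100 nM

In a functional assay on HepG2 cells (Homo sapiens) for cytotoxicity, read by MTT assay, with a stated time of 72 h (on this read-out higher numbers stand for weaker inhibition and lower numbers for stronger inhibition), compound 1 gives only a limit of the assay, > 60000 nM. Compound 2 gives 3180 nM and compound 3 gives 23100 nM; of the two numbers, compound 3 stands highest, and the step of a 7.3-fold higher number from compound 2 to compound 3 (0.86 log units; beyond the scatter) lies beyond the scatter. Compound 4 `Cc1cc(=O)n(-c2cccc(C(F)(F)F)c2)nc1C(=O)Nc1ccc(Oc2ncnc3[nH]ccc23)c(F)c1` differs from compound 3 by trifluoromethyl in place of fluoro on an aromatic carbon. Among the measured compounds shown here, the only measured step concerns a different ring, so no measured step bears directly on this change. A step of no more than the scatter is therefore expected, in either direction. Compound 4 is estimated at 20000 nM, within 7000 nM to 60000 nM, meaning an expected step of a 1.2-fold lower number from compound 3 to compound 4 (0.06 log units; within the scatter).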

Compound 4, half-maximal inhibitory concentration: 26300 nM
Estimate against measurement, compound 4: 1.3-fold (0.12 log units) below, within the range that was stated.
By their numbers in this assay, from the lowest: compound 2; then compounds 3 and 4 (each within the scatter of the next). At a limit, above all of these: compound 1.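

Going from 3-fluorophenyl to 3-(trifluoromethyl)phenyl gives a 1.1-fold higher number from compound 3 to compound 4 (0.06 log units; within the scatter) in this assay, so this position accepts the larger group with no change beyond the usual scatter. Among the compounds shown here, the only earlier step, a 7.3-fold higher number from compound 2 to compound 3 (0.86 log units; beyond the scatter), came from a change on a different ring, which makes this the first view of this position. Nothing shown here bears on why the number holds steady.

As far as these compounds go, whether an amine, a carboxylic acid or a longer chain at this position would also leave the number in place remains open. So does the outcome of the same swap on compound 2.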